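Replacing the bromonaphthalene group of compound 3

This account rests on a few compounds, and the source may have more. Where it says the series, first, only, none or still open, it means among the compounds named here.

Of the compounds shown here, three have been measured in a functional assay on A549 cells (Homo sapiens) for antiproliferative activity, with a stated time of 5 days; on this read-out higher numbers stand for weaker inhibition and lower numbers for stronger inhibition. Compound 1 `CC1OC2(C=CC(=O)C=C2)N(c2nc(-c3ccc4ccccc4c3)nn2-c2ccccc2)C1=O` gives 310 nM, compound 2 `CC1OC2(C=CC(=O)C=C2)N(c2nc(-c3cccc4ccccc34)nn2-c2ccccc2)C1=O` gives 180 nM and compound 3 `O=C1C=CC2(C=C1)OCC(=O)N2c1nc(-c2ccc3ccccc3c2Br)nn1-c1ccccc1` gives 100 nM. The number for compound 3 is the lowest of the three, but it lies within the usual scatter of compound 2 and beyond the scatter only from compound 1.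

Compound 4 `O=C1C=CC2(C=C1)OCC(=O)N2c1nc(-c2cccc3ccccc23)nn1-c1ccccc1` has not yet been measured. It differs from compound 3 at one place, an aromatic carbon of a five-membered aromatic ring with 3 nitrogen, where naphthalen-1-yl stands in place of 1-bromonaphthalen-2-yl (naphthalen-1-yl in place of 1-bromonaphthalen-2-yl on an aromatic carbon).

For the measured compounds named here, one measured step bears on this change: a 1.7-fold lower number from compound 1 to compound 2 (0.24 log units; within the scatter). It also brings in naphthalen-1-yl, but in place of naphthalen-2-yl. Going by the values given here, no measured pair shows the loss of the bromine alone, so the uncertainty is wide, and no step beyond the scatter is expected in this assay. The expected step is a 1.5-fold higher number from compound 3 to compound 4 (0.18 log units; within the scatter). For compound 4 the estimated value is 150 nM, with an expected range from 50 nM to 420 nM.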

Compound 4, half-maximal inhibitory concentration: 80 nM
Estimate against measurement, compound 4: 1.9-fold (0.27 log units) above; the range from low to high includes it.
By their numbers in this assay, from the lowest: compounds 4, 3, 2 and 1 (each within the scatter of the next, the first and the last beyond it).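

Swapping 1-bromonaphthalen-2-yl for naphthalen-1-yl on the ring with 3 nitrogen gives a 1.3-fold lower number from compound 3 to compound 4 (0.10 log units; within the scatter) in this assay, so the two groups cannot be told apart here, and this position accepts a naphthalene without the bromine. For the compounds shown here, the other new comparison concerns a different place, the saturated ring carbon, where hydrogen in place of methyl gives a 2.3-fold lower number from compound 2 to compound 4 (0.35 log units; beyond the scatter), the first step between compounds differing in one place that lies beyond the scatter, though only modestly. No independent evidence is available to explain either step.

On these data alone, it remains open how a single phenyl ring, an amine or a carboxylic acid at the aromatic position would compare with naphthalen-1-yl. As far as these compounds go, it is also open how a longer chain such as ethyl on the saturated ring carbon would compare with methyl and hydrogen.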